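A few compounds are considered here, and "the series" means these few. Any claim that something is new, unique, unknown or untested is made for them only; others in the source may bear on it.

Working notes on the series. Compound 1 `O=C(NCc1ccc(CNS(=O)(=O)c2ccccc2F)cc1)c1cc2ccccn2n1` carries a 2-fluorophenyl group on the sulfonyl sulfur; in an assay on cells for displacement of a labelled ligand from C-X-C chemokine receptor type 4 (Homo sapiens), read by fluorescence and microscopy, with stated times of 10 min and 30 min (on this read-out higher numbers stand for an effect only at larger amounts of compound and lower numbers for an effect already at smaller amounts), compound 1 gives 100 nM. Compound 3 `Cc1nnsc1C(=O)NCc1ccc(CNS(=O)(=O)c2ccc(F)c(F)c2)cc1` in this assay gives 10 nM. Compound 2 `O=C(NCc1ccc(CNS(=O)(=O)c2ccc(F)c(F)c2)cc1)c1cnc2ccccn12` reaches only a limit of this assay, > 1000 nM, and no number. Among the two numbers shown, compound 1 stands highest, with compound 3 nearest, a step beyond the scatter. For the measured compounds named here, the only step measured within one change is an at least 100-fold lower number from compound 2 to compound 3 (2.00 log units; beyond the scatter), a change on the carbonyl carbon; the limit of > 1000 nM in this assay, at which 1 of the 3 values shown sits, sets the starting point of that step.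

Compound 4 `O=C(NCc1ccc(CNS(=O)(=O)c2ccc3c(c2)CCO3)cc1)c1cc2ccccn2n1` differs from compound 1 by a group of 9 heavy atoms (8 carbon, 1 oxygen; one five-membered non-aromatic ring with 1 hetero atom, one six-membered aromatic ring of carbon only) in place of a group of 7 heavy atoms (6 carbon, 1 fluorine; one six-membered aromatic ring of carbon only), on a sulfonyl sulfur. Going by the values given here, this change sits on the sulfonyl sulfur, where no measured step falls; the step from compound 2 to compound 3 concerns the carbonyl side only and gives no direct guide here. No step beyond the scatter is therefore expected, no change at the digits printed from compound 1 to compound 4 (within the scatter), though the range is kept wide for lack of a comparable change. Compound 4 is estimated at 100 nM in this assay, within 25 nM to 400 nM.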

Compound 4, effective concentration (reported as EC, without a stated level of effect): 1 nM
Compound 4: middle estimate off by 100-fold (2.00 log units), on the high side; measured number outside the range, below it.
By their numbers in this assay, from the lowest: compound 4; then compound 3; then compound 1. At a limit, above all of these: compound 2.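

For the compounds shown here, the group on the sulfonyl sulfur, which had no measured step until now, proves to be a place of large change: the group with the five-membered non-aromatic ring, in place of 2-fluorophenyl, gives a 100-fold lower number from compound 1 to compound 4 (2.00 log units; beyond the scatter) on an unchanged remainder of the molecule. Going by these compounds alone, this step has a number at both ends, whereas the only earlier step, on the carbonyl carbon, started from a limit. No measurement shown bears on what lies behind this step.

Still open, from the compounds shown here alone, is which part of the entering group carries the step, the ring oxygen or the non-aromatic ring itself; a plain phenyl or a 4-methoxyphenyl group on the sulfonyl sulfur would begin to separate these. Also open, going by these compounds, is whether the step holds when the group of compound 4 is paired with the carbonyl group of compound 3.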